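This account rests on a few compounds, and the source may have more. Where it says the series, first, only, none or still open, it means among the compounds named here.

Values in an ADME assay on WI-38 cells (Homo sapiens) for cytotoxicity, read by MTT assay, with a stated time of 48 h (on this read-out lower numbers stand for stronger inhibition and higher numbers for weaker inhibition), for the series so far:
compound 1 `CC(C)(Oc1ccc(Cl)cc1)C(=O)NCCOC(=S)Nc1ccc(F)cc1` gives > 800000 nM (a limit of the assay)
compound 2 `COc1ccc(NC(=S)OCCNC(=O)C(C)(C)Oc2ccc(Cl)cc2)cc1` gives 780000 nM (the only number)

Among the compounds with values here, compound 2 holds the only number so far, while compound 1 stands at a limit. Next comes compound 3 `Cc1ccc(NC(=S)OCCNC(=O)C(C)(C)Oc2ccc(Cl)cc2)cc1` with methyl in place of methoxy on an aromatic carbon, para to a large group (methyl in place of methoxy on an aromatic carbon). Within the data shown here, the one measured step bearing on this is an at least 1.0-fold lower number from compound 1 to compound 2 (0.01 log units; that floor lies within the scatter) for methoxy in place of fluoro on an aromatic carbon. The step expected in this assay is therefore a 1.0-fold lower number from compound 2 to compound 3 (0.02 log units; within the scatter) and nothing beyond the scatter is expected in either direction. For compound 3 the estimate is 750000 nM (expected range 400000 nM to 1300000 nM).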

Compound 3, half-maximal inhibitory concentration: > 800000 nM
Compound 3: a limit, no number; the forecaster's own chance of this, stated with the estimate: 35%; at least 1.0-fold (0.02 log units) between middle value and limit.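

In this assay, 4-methoxyphenyl to 4-methylphenyl gives an at least 1.0-fold higher number from compound 2 to compound 3 (0.01 log units; that floor lies within the scatter), a floor that leaves the true size of the step open. Compound 3 gives > 800000 nM, which is a limit of the assay and not a number. The steps involving two limits cannot be read, and most of the series now sits at one value: the limit of > 800000 nM in this assay, at which 2 of the 3 values shown sit.

On these data alone, compound 2 gives 780000 nM, and whether an amine or a carboxylic acid on this aromatic carbon, para to a large group, would give a clearly lower number remains open.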